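Replacing Nitro by Amino: Expected Cytotoxicity of Compound 4

This account rests on a few compounds, and the source may have more. Where it says the series, first, only, none or still open, it means among the compounds named here.

Compound 1 `C=CCc1cc(C)c(Oc2ccc([N+](=O)[O-])c(Nc3ccc(C#N)cc3)n2)c(C)c1` and compound 2 `C=CCc1cc(C)c(Oc2ccc(N)c(Nc3ccc(C#N)cc3)n2)c(C)c1` were tested in an ADME assay on MT2 cells (Homo sapiens) for cytotoxicity, read by XTT assay, with a stated time of 4 days (on this read-out higher numbers stand for lower toxicity in this test and lower numbers for higher toxicity in this test), where compound 1 gives 39700 nM and compound 2 gives 14000 nM. The change between them, (amino in place of nitro on an aromatic carbon), made a step of a 2.8-fold lower number from compound 1 to compound 2 (0.45 log units; beyond the scatter). Compound 3 `Cc1cc(/C=C/C#N)cc(C)c1Oc1cc(Nc2ccc(C#N)cc2)c(N)cc1[N+](=O)[O-]` rests on a different core; the difference between the two cores is not broken down here. In this assay compound 3 gives 88200 nM, the highest of the three numbers. Compound 4 `Cc1cc(/C=C/C#N)cc(C)c1Oc1cc(Nc2ccc(C#N)cc2)c(N)cc1N` carries the same kind of change, (amino in place of nitro on an aromatic carbon), but at a different place: in compound 2 the amino sits on a six-membered aromatic ring with 1 nitrogen, ortho to a (4-cyanophenyl)amino group, two atoms from the ring nitrogen and para to a large group, whereas in compound 4 it sits on a six-membered aromatic ring of carbon only, ortho to a large group, meta to an amino group and para to a (4-cyanophenyl)amino group. A step of about a 2.7-fold lower number from compound 3 to compound 4 (0.43 log units; beyond the scatter) is expected, resting on the earlier step of a 2.8-fold lower number from compound 1 to compound 2 (0.45 log units; beyond the scatter). Compound 4 is therefore estimated at 33000 nM in this assay.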

Compound 4, half-maximal cytotoxic concentration: 18900 nM
The estimate for compound 4 lay 1.7-fold (0.24 log units) above the measured number, and the stated range covers the measured number.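

In this assay, amino in place of nitro again gave a lower number, which here stands for higher toxicity in this test, with a 4.7-fold lower number from compound 3 to compound 4 (0.67 log units; beyond the scatter). Set beside the earlier step, the change carried from one core to the other in direction and in size: the same change on two cores in this assay, a 2.8-fold lower number (0.45 log units; beyond the scatter) from compound 1 to compound 2 and a 4.7-fold lower number (0.67 log units; beyond the scatter) from compound 3 to compound 4, 1.6-fold (0.22 log units) apart, within the scatter of two such steps. For the compounds shown here, this rests on only two pairs, with the amino at a different place in each, so it does not show that the step would hold on other cores or at other places, nor does it show why the number falls.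

The compounds shown leave open whether an acetamide or a hydroxyl in place of the nitro would move the number in the same way. They also leave open what plain hydrogen at that place would give.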